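The compounds below may be only part of what the source reports. "The series", "measured", "known", "first", "only" and "open" are said of these compounds alone.

Compound 1 `Cc1c(C(=O)N/N=C\c2c(O)cccc2F)oc2cccc(O)c12` gives 8050 nM in a functional assay on PC-3 cells (Homo sapiens) for inhibition (on this read-out higher numbers stand for weaker inhibition and lower numbers for stronger inhibition), the lowest of the two numbers in hand. Its nearest neighbour is compound 2 `Cc1c(C(=O)N/N=C\c2cccc(F)c2O)oc2cccc(O)c12`, which in this assay gives 12700 nM, a step of a 1.6-fold higher number from compound 1 to compound 2 (0.20 log units; within the scatter). Compound 3 `Cc1c(C(=O)N/N=C\c2ccc(Br)cc2O)oc2cccc(O)c12` differs from compound 1 by 4-bromo-2-hydroxyphenyl in place of 2-fluoro-6-hydroxyphenyl on a carbon with a double bond to nitrogen. For the measured compounds named here, the only measured step that bears on this change, the one between compound 1 and compound 2, also exchanges one substituted ring for another and stays within the scatter, so no step beyond the scatter is expected in either direction. Compound 3 is therefore estimated at 8000 nM, between 3000 nM and 25000 nM, an expected step of a 1.0-fold lower number from compound 1 to compound 3 (0.00 log units; within the scatter).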

Compound 3, half-maximal inhibitory concentration: 2050 nM
Beside the measured number, compound 3's estimate is 3.9-fold (0.59 log units) above it; measured number below the stated range.
By their numbers in this assay, from the lowest: compound 3; then compounds 1 and 2 (each within the scatter of the next).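

In this assay, the group on a carbon with a double bond to nitrogen can move the number beyond the scatter: 4-bromo-2-hydroxyphenyl brings a 3.9-fold lower number from compound 1 to compound 3 (0.59 log units; beyond the scatter) and a 6.2-fold lower number from compound 2 to compound 3 (0.79 log units; beyond the scatter) while the two fluorinated rings stayed within the scatter of each other. This change replaces fluorine with bromine and also alters the substitution pattern, so these two contributions cannot be separated. Nothing available explains the lower number. As far as these compounds go, it remains open whether bromine itself or its ring position carries the step. Also open, from the compounds shown here alone, is how 4-chloro-2-hydroxyphenyl, 4-methoxy-2-hydroxyphenyl or an amine in place of the bromine would read.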